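This account rests on a few compounds, and the source may have more. Where it says the series, first, only, none or still open, it means among the compounds named here.

Compound 1, `Nc1nc(NC2CC2)c2ncn(/C=C3/CC3(CO)CO)c2n1`, in an ADME assay on CCRF-HSB-2 cells (Homo sapiens) for cytotoxicity, with a stated time of 7 days; on this read-out lower numbers stand for higher toxicity in this test and higher numbers for lower toxicity in this test: > 20000 nM, a limit of the assay rather than a number.
Compound 2, `Nc1nc(NC2CCCC2)c2ncn(/C=C3/CC3(CO)CO)c2n1`, in this assay: > 20000 nM, again a limit of the assay.
Compound 3, `CCCCCCCCSc1nc(N)nc2c1ncn2/C=C1/CC1(CO)CO`, in this assay: 60000 nM.

Compound 3 is the only one of the three with an actual number, as the note the limit of > 20000 nM in this assay, at which 2 of the 3 values shown sit, records for the other two. The three compounds share one core and differ only in the group on one aromatic carbon. The step that the two limits leave unreadable from compound 1 to compound 2 compares two limits and cannot be read. The steps a step that the limit leaves unreadable from compound 1 to compound 3 and a step that the limit leaves unreadable from compound 2 to compound 3 each run from a limit to a number, so their size also cannot be read. Among the measured compounds shown here, compound 4, `CCCCNc1nc(N)nc2c1ncn2/C=C1/CC1(CO)CO`, is not yet measured. butylamino in place of octylsulfanyl on an aromatic carbon Compound 4 thus carries butylamino, an amine like the cyclopropylamino of compound 1 and the cyclopentylamino of compound 2, both of which gave only limits, while the single number comes from compound 3 with its octylsulfanyl group. With no readable measured step, there is no basis for predicting a shift beyond the scatter, and it seems likely that compound 4 will again return only a limit. Compound 4 is estimated at 40000 nM, between 15000 nM and 150000 nM, an expected step of a 1.5-fold lower number from compound 3 to compound 4 (0.18 log units; within the scatter).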

Compound 4, half-maximal cytotoxic concentration: > 20000 nM
Compound 4: no number, only a limit (the forecaster's own chance of this, stated with the estimate: 60%); the middle value is on the limit's open side.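

Compound 4 gives only a limit in this assay, not a number, so its steps to compound 1, compound 2 and compound 3 cannot be read: the limit of > 20000 nM in this assay, at which 3 of the 4 values shown sit.

Left open is whether compound 1, compound 2 and compound 4 differ from one another at all, and whether any of them truly differs from compound 3, which carries octylsulfanyl.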